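The source may report more compounds than this note shows. Statements on the series, on what has been measured and on what is new or still open speak of the compounds shown alone.

The measured compounds in a physicochemical assay for lipophilicity, read by HPLC, at pH 7.4 (a higher number here means a more lipophilic compound, a lower number a more polar compound), are:

compound 1, `CNCc1cn(S(=O)(=O)c2ccco2)c(-c2cccnc2F)c1F` — compound 1 gives 0.2
compound 2, `CNCc1cn(S(=O)(=O)c2ccccn2)c(-c2cccnc2F)c1F` — compound 2 gives 0.44
compound 3, `CNCc1cn(S(=O)(=O)c2ccc(OC)cn2)c(-c2cccnc2F)c1F` — compound 3 gives 0.64

Compound 2 sits second highest of the three numbers in this assay. Its nearest neighbour is compound 3, and the step of a number 0.20 log units higher from compound 2 to compound 3 (within the scatter). Compound 1 lies furthest from it, and the step of a number 0.24 log units higher from compound 1 to compound 2 (within the scatter). Both of these steps are small, and only the longer step of a number 0.44 log units higher from compound 1 to compound 3 (beyond the scatter) reaches beyond the scatter.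

Compound 4, `CNCc1cn(S(=O)(=O)c2cnccc2C)c(-c2cccnc2F)c1F`, has not yet been measured in this assay. It differs from compound 2 in one place: 4-methylpyridin-3-yl in place of pyridin-2-yl on a sulfonyl sulfur. The two steps that touch compound 2 both bear on this change, since each swaps or decorates the ring on the sulfonyl sulfur, and each stayed within the scatter. For the measured compounds named here, none of the measured steps shows exactly the exchange of pyridin-2-yl for 4-methylpyridin-3-yl, so the expectation rests on the small size of the nearby steps.

Compound 4 is therefore expected to give a value in this assay a little above compound 2, estimated as 0.7 with a range from 0.4 to 1. The estimated step of a number 0.26 log units higher from compound 2 to compound 4 (within the scatter) is expected to be small, comparable to the measured neighbouring steps.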

Compound 4, distribution coefficient: 0.43
Compound 4: middle estimate off by 0.27 log units, on the high side; low and high end bracket the measured number.
By their numbers in this assay, from the lowest: compounds 1, 4, 2 and 3 (each within the scatter of the next, the first and the last beyond it).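

In this assay, the exchange on the sulfonyl sulfur that gives compound 4 is a change of both ring attachment and decoration, yet it amounts to a number 0.01 log units lower from compound 2 to compound 4 (within the scatter) and so cannot be told apart from no change at all. The two other new steps, a number 0.21 log units lower from compound 3 to compound 4 (within the scatter) and a number 0.23 log units higher from compound 1 to compound 4 (within the scatter), are also unresolved, so compound 4 stands within the scatter of every other compound shown, even though compound 1 and compound 3 are separated by more than the scatter. No supporting measurement is available to account for this flat result.

Because 4-methylpyridin-3-yl differs from pyridin-2-yl in two ways at once, the compounds shown cannot separate the contribution of the methyl group from that of the ring attachment, and an undecorated pyridin-3-yl would be needed to do so. From the compounds shown here alone, all four compounds also carry an aromatic ring on the sulfonyl sulfur, so it remains open whether a group of another kind there, such as a carboxylic acid, an amine or a longer alkyl chain, would produce a step beyond the scatter.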